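The compounds below may be only part of what the source reports. "The series", "measured", "known", "first", "only" and "open" are said of these compounds alone.

Values in a functional assay on U-937 cells (Homo sapiens) for cytotoxicity, read by MTT assay, with a stated time of 48 h; a lower number here means a stronger inhibitor, a higher number a weaker inhibitor:
- Compound 1 `Fc1ccc2nc(-c3ccccc3)nc(Nc3ccccc3)c2c1`: > 50000 nM, a limit
- Compound 2 `Fc1cccc(-c2nc(Nc3ccccc3)c3cc(F)ccc3n2)c1`: 45500 nM
- Compound 3 `Fc1cccc(-c2nc(Nc3ccccc3F)c3cc(F)ccc3n2)c1`: > 50000 nM, a limit

Compound 3 stands at > 50000 nM, and this is a limit. Compound 4 `Oc1ccc(Nc2nc(-c3cccc(F)c3)nc3ccc(F)cc23)cc1` carries 4-hydroxyphenyl in place of 2-fluorophenyl on a nitrogen on an aromatic ring. For the measured compounds named here, two measured steps bear on this change, each a fluoro in place of hydrogen on an aromatic carbon: an at least 1.0-fold lower number from compound 1 to compound 2 (0.04 log units; that floor lies within the scatter), and an at least 1.0-fold higher number from compound 2 to compound 3 (0.04 log units; that floor lies within the scatter). Neither brings in a hydroxyl, so they are only a weak guide. With both of them so small, only a modest shift towards a lower number is expected in this assay, namely an at least 1.6-fold lower number from compound 3 to compound 4 (0.22 log units; that floor lies within the scatter). Compound 4 is estimated at 30000 nM, with an expected range from 8000 nM to 50000 nM.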

Compound 4, half-maximal inhibitory concentration: > 50000 nM
Compound 4 gave a limit, no number; the forecaster's own chance of this, stated with the estimate: 40%; middle value at least 1.6-fold (0.22 log units) away from the limit.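

In this assay, the step between compound 3 and compound 4 cannot be read, as both values are limits. Bringing in a hydroxyl gives an at least 1.0-fold higher number from compound 2 to compound 4 (0.04 log units; that floor lies within the scatter), so the hydroxyl of compound 4, like the fluoro of compound 3, brings no readable gain on this ring. The series mostly sits at a single limit: the limit of > 50000 nM in this assay, at which 3 of the 4 values shown sit.

As far as these compounds go, whether an amine or a carboxylic acid on this phenyl ring would give a measurable value in this assay stays open. The same holds for a longer chain on the nitrogen in place of the ring.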